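The compounds below may be only part of what the source reports. "The series", "measured", "known", "first", "only" and "open" are said of these compounds alone.

Working notes on the step from compound 2 `Cc1ccc(S(=O)(=O)N[C@@H](CC(=O)NC(C)(C)C)C(=O)NCCNC(=O)c2ccccc2Cl)cc1` to compound 3 `Cc1ccc(S(=O)(=O)N[C@@H](CC(=O)NC(C)(C)C)C(=O)NCCNC(=O)c2ccccn2)cc1`, with compound 1 `Cc1ccc(S(=O)(=O)N[C@@H](CC(=O)NC(C)(C)C)C(=O)NCCNC(=O)c2cccc(C(F)(F)F)c2)cc1` as the only other point. In an ADME assay on Karpas-1106P cells (Homo sapiens) for cytotoxicity (a higher number here means that more compound is needed for the effect, a lower number that less compound is needed), compound 1 gives only a limit, > 11100 nM. In this assay compound 2 likewise gives only a limit, > 11100 nM. The step that the two limits leave unreadable from compound 1 to compound 2 is unreadable, both values sitting at the limit of > 11100 nM in this assay, at which 2 of the 2 values shown sit. Compound 2 thus stands at the limit, with no number of its own. The change to compound 3 is pyridin-2-yl in place of 2-chlorophenyl on a carbonyl carbon. Going by the values given here, no measured step reads across it, so an expected step that the limit leaves unreadable from compound 2 to compound 3 is set, none beyond the scatter. For compound 3 the expected value in this assay is 15000 nM, within 7000 nM to 40000 nM, most likely again only a limit.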

Compound 3, half-maximal effective concentration: > 11100 nM
Compound 3 ended at the assay's limit; the forecaster's own chance of this, stated with the estimate: 80%; the middle value does not contradict the limit.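

Going by these compounds alone, compound 3 joins compound 1 and compound 2 at the limit, so no step among the three can be read: the limit of > 11100 nM in this assay, at which 3 of the 3 values shown sit. The compounds shown leave open whether the 3-(trifluoromethyl)phenyl, 2-chlorophenyl and pyridin-2-yl groups differ at all in half-maximal effective concentration.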